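This account rests on a few compounds, and the source may have more. Where it says the series, first, only, none or still open, it means among the compounds named here.

Compounds measured so far in a functional assay for antagonist activity at Adrenergic receptor alpha-1 (Rattus norvegicus); a higher number here means weaker binding, a lower number tighter binding:
- compound 1, `COc1ccc(Cl)cc1N1CCN(CCNC(=O)c2cc3ccccc3o2)CC1`, gives 2340 nM
- compound 2, `Cc1ccc(N2CCN(CCNC(=O)c3cccnc3)CC2)cc1`, gives 295 nM
- compound 3, `Cc1ccc(N2CCN(CCNC(=O)c3cc4ccccc4o3)CC2)c(C)c1`, gives 43.7 nM

Within the data shown here, compound 3 has the lowest number of the three in this assay; compound 2 stands nearest to it, and compound 1 furthest, the latter separated by the single change a 54-fold lower number from compound 1 to compound 3 (1.73 log units; beyond the scatter).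

Compound 4, `Cc1ccc(N2CCN(CCNC(=O)c3ccncc3)CC2)c(C)c1`, is not yet measured. It differs from compound 3 in one place: pyridin-4-yl in place of 1-benzofuran-2-yl on a carbonyl carbon. Among the measured compounds shown here, no measured step changes the amide-side group alone, so nothing bears directly on this change. Compound 2, which carries a pyridin-3-yl on the carbonyl carbon together with a 4-methylphenyl on the ring nitrogen, gives 295 nM, while compound 3 with the 1-benzofuran-2-yl gives 43.7 nM, but those two compounds differ in two places at once.

With that in mind, compound 4 is expected to show a higher number than compound 3, a step of about a 5.7-fold higher number from compound 3 to compound 4 (0.76 log units; beyond the scatter), with the estimate for compound 4 in this assay at 250 nM, within a range from 60 nM to 1000 nM.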

Compound 4, dissociation constant: 85.1 nM
Beside the measured number, compound 4's estimate is 2.9-fold (0.47 log units) above it; measured number inside the range.
By their numbers in this assay, from the lowest: compounds 3 and 4 (each within the scatter of the next); then compound 2; then compound 1.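

Within this assay, the amide side now has a reading of its own, as the earlier single-place step concerned only the group on the ring nitrogen. With the 2,4-dimethylphenyl held fixed, the change on the carbonyl carbon gives a 1.9-fold higher number from compound 3 to compound 4 (0.29 log units; within the scatter) and so separates 1-benzofuran-2-yl, with its 9 heavy atoms, from pyridin-4-yl, with its 6, by no more than the usual scatter. No measurement available here speaks to why the two groups read alike.

This single pair leaves open whether the same holds with the 5-chloro-2-methoxyphenyl of compound 1 on the ring nitrogen. Also open, as far as these compounds go, is how an unsubstituted phenyl, a simple alkyl chain or a carboxylic acid on the carbonyl carbon would read against these two groups.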